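A few compounds are considered here, and "the series" means these few. Any claim that something is new, unique, unknown or untested is made for them only; others in the source may bear on it.

Measured so far:

compound 1 `COc1ccc2c(O[C@@H]3C[C@H]4C(=O)N[C@]5(C(=O)NS(=O)(=O)C6CC6)C[C@H]5/C=C\CCCCCNC(=O)N4C3)cc(-c3nc(C(C)C)cs3)nc2c1`: in an in vivo ADME assay on the whole organism (strain Sprague-Dawley) for pharmacokinetics, with Rattus norvegicus as the target, at a dose of 2 mg/kg by the intravenous route (a lower number here means slower removal, a higher number faster removal of the compound), compound 1 gives 9.17 mL/min/kg.
compound 2 `COc1ccc2c(O[C@@H]3C[C@H]4C(=O)N[C@]5(C(=O)NS(=O)(=O)C6CC6)C[C@H]5/C=C\CCCCNC(=O)N4C3)cc(-c3nc(C(C)C)cs3)nc2c1`: in this assay compound 2 gives 15.7 mL/min/kg.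

Of the two numbers recorded in this assay, compound 2 gives the larger one, but compound 1 falls within the usual scatter of it, so the two compounds cannot be told apart on this read-out. The pair offers no comparison between two measured compounds that differ in one place, so nothing anchors the size of a single structural change here.

Compound 3 `COc1ccc2c(O[C@@H]3C[C@H]4C(=O)N[C@]5(C(=O)NS(=O)(=O)C6CC6)C[C@H]5/C=C\CCCCN(C)C(=O)N4C3)cc(-c3nc(C(C)C)cs3)nc2c1` differs from compound 2 by methyl in place of hydrogen on an amide-type nitrogen in a ring. Among the compounds with values here, with no measured single-change step available, the expectation rests on the two values alone. For the step from compound 2 to compound 3 in this assay a change of a 1.1-fold higher number from compound 2 to compound 3 (0.03 log units; within the scatter) is expected, not beyond the scatter of repeated measurements. Compound 3 is estimated to give 17 mL/min/kg in this assay, with a likely range from 8 mL/min/kg to 35 mL/min/kg.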

Compound 3, clearance: 27.5 mL/min/kg
Beside the measured number, compound 3's estimate is 1.6-fold (0.21 log units) below it; measured number inside the range.
By their numbers in this assay, from the lowest: compounds 1, 2 and 3 (each within the scatter of the next, the first and the last beyond it).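

Within the data shown here, this is the first single-place step: methyl in place of hydrogen on the amide-type nitrogen in the ring gives, in this assay, a 1.8-fold higher number from compound 2 to compound 3 (0.24 log units; within the scatter). A step of this size lies within the scatter, so this replacement does not separate the two compounds on this read-out, and the amide hydrogen at this position is not shown to matter for clearance. No measurement is at hand that bears on the reason for this result.

Still open, from the compounds shown here alone, is whether ethyl or a longer chain such as 2-methoxyethyl on this nitrogen would give a step beyond the scatter in this assay. Also open, going by these compounds, is whether methyl on the corresponding nitrogen of compound 1 would give a step of similar size.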